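Biaryl amide TRPV1 antagonists: nitrile to carboxylic acid

This account rests on a few compounds, and the source may have more. Where it says the series, first, only, none or still open, it means among the compounds named here.

Compound 1 `N#Cc1ccc(NC(=O)c2ccc(-c3ncccc3C(F)(F)F)cc2)cc1`: 417 nM
Compound 2 `Cc1cccnc1-c1ccc(C(=O)Nc2ccc(C(F)(F)F)cc2)cc1`: 65 nM
Compound 3 `CC(C)(C)c1ccc(NC(=O)c2ccc(-c3ncccc3C#N)cc2)cc1`: 30 nM

Three measured compounds share the biaryl amide core and differ in the substituent on the pyridine and in the group on the aniline ring. In a functional assay for antagonist activity at transient receptor potential cation channel subfamily V member 1 (Homo sapiens), read by FLIPR (a higher number here means a weaker inhibitor, a lower number a stronger inhibitor), compound 3 gives 30 nM, the lowest of the three numbers. Compound 2 gives 65 nM, which lies beyond the scatter of compound 3, and compound 1 gives 417 nM, the furthest from compound 3. No two of these compounds differ in one place only, so no single step between measured compounds can be read off.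

Compound 4 `CC(C)(C)c1ccc(NC(=O)c2ccc(-c3ncccc3C(=O)O)cc2)cc1` has not yet been measured. It differs from compound 3 in one place: carboxy in place of cyano on an aromatic carbon. The cyano group leaves and a carboxy group enters, bringing one hydrogen-bond donor where there was none. Among the measured compounds shown here, no measured pair in this set shows a change of this kind, so the expectation rests on the structural change alone.

In this assay compound 4 is expected to give 3000 nM, with a range of 600 nM to 15000 nM. The expected step is a 100-fold higher number from compound 3 to compound 4 (2.00 log units; beyond the scatter), a loss of potency well beyond the scatter, with a fair chance that only a limit is reported.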

Compound 4, half-maximal inhibitory concentration: > 4000 nM
Compound 4 gave a limit, no number; the forecaster's own chance of this, stated with the estimate: 25%; middle value at least 1.3-fold (0.12 log units) from the limit.
By their numbers in this assay, from the lowest: compound 3; then compound 2; then compound 1. At a limit, above all of these: compound 4.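

In this assay compound 4 is reported only as a limit, > 4000 nM. As far as these compounds go, this gives the set its first comparison of compounds differing in one place, an at least 130-fold higher number from compound 3 to compound 4 (2.12 log units; beyond the scatter), so at this position, on an aromatic carbon two atoms from the ring nitrogen, the change from 3-cyanopyridin-2-yl to 3-carboxypyridin-2-yl costs a large amount of potency with the tert-butyl group held constant on the aniline ring, and the true size of that loss stays unknown. Among the compounds shown here, this is the only such reading in the set: the limit of > 4000 nM in this assay, at which 1 of the 4 values shown sits.

A single pair cannot separate the hydrogen-bond donor that carboxy brings from the other differences between the two groups, and a primary carboxamide, a methyl ester or a hydroxymethyl group at the same position would be needed to tell them apart. For the compounds shown here, whether the change costs as much with the other aniline ring groups, the cyano of compound 1 or the trifluoromethyl of compound 2, also stays open, as no pair here carries the change on either of those groups.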